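The source may report more compounds than this note shows. Statements on the series, on what has been measured and on what is new or still open speak of the compounds shown alone.

Measured in a physicochemical assay for lipophilicity, measured as octanol-water partition; a higher number here means a more lipophilic compound, a lower number a more polar compound:
- compound 1 (`O=C(NNc1ccnc2cc(Cl)ccc12)c1ccccc1/N=C/c1ccc(Cl)cc1Cl`) gives 6.22
- compound 2 (`O=C(NNc1ccnc2cc(Cl)ccc12)c1ccccc1/N=C/c1ccc(Br)cc1`) gives 5.76
- compound 3 (`O=C(NNc1ccnc2cc(Cl)ccc12)c1ccccc1/N=C/c1ccc([N+](=O)[O-])cc1`) gives 4.58

Compound 3 stands lowest of the three, with both of the others beyond the scatter above it. Compound 4 (`O=C(NNc1ccnc2cc(Cl)ccc12)c1ccccc1/N=C/c1ccc(O)cc1`) has hydroxy in place of nitro on an aromatic carbon, para to a large group (hydroxy in place of nitro on an aromatic carbon). It has not yet been measured.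

The measured step closest to this change is the one with nitro in place of bromo (a number 1.18 log units lower from compound 2 to compound 3 (beyond the scatter)), and it was large. Putting 4-nitrophenyl in place of 2,4-dichlorophenyl also gave a large step (a number 1.64 log units lower from compound 1 to compound 3 (beyond the scatter)), while 4-bromophenyl in place of 2,4-dichlorophenyl gave a modest one (a number 0.46 log units lower from compound 1 to compound 2 (beyond the scatter)). Within the data shown here, these steps show how far a change of group on this part of the molecule has moved the number so far. None of them brings in hydroxy, however, so the data do not fix the direction for this change.

A modest fall is expected, though with limited confidence, and the estimated step is (a number 0.28 log units lower from compound 3 to compound 4 (within the scatter)). Compound 4 is estimated at 4.3 (expected range 3.8 to 4.8).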

Compound 4, partition coefficient: 4.65
Estimate against measurement, compound 4: 0.35 log units below; the range from low to high includes it.
By their numbers in this assay, from the lowest: compounds 3 and 4 (each within the scatter of the next); then compound 2; then compound 1.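

In this assay, at this place on the aromatic ring, para to a large group, hydroxy proves indistinguishable from nitro: the step reads a number 0.07 log units higher from compound 3 to compound 4 (within the scatter) even though nitro has no hydrogen-bond donor and hydroxy has one. Measured against the other two compounds, hydroxy in place of bromo gives a number 1.11 log units lower from compound 2 to compound 4 (beyond the scatter) and 4-hydroxyphenyl in place of 2,4-dichlorophenyl gives a number 1.57 log units lower from compound 1 to compound 4 (beyond the scatter) and both are large, much like the matching steps to the nitro compound, a number 1.18 log units lower from compound 2 to compound 3 (beyond the scatter) and a number 1.64 log units lower from compound 1 to compound 3 (beyond the scatter) in turn, so among these four compounds hydroxy and nitro stand together, well apart from the bromo and dichloro compounds. Nothing in the data accounts for why these two different groups match at this place.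

The compounds shown leave open whether an amine, a carboxylic acid or a methoxy group at this place would stand with hydroxy and nitro or nearer to bromo. They also leave open whether the match between hydroxy and nitro would hold on a different core.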